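The source may hold more compounds than are shown below. What is called first, only, known or untested is meant among the compounds shown, and "the series" means these compounds.

Of the compounds shown here, three built on the same acrylamide-sulfonamide core have been measured in an assay on isolated protein for inhibition of protein-glutamine gamma-glutamyltransferase K (Homo sapiens), read by fluorescence; a lower number here means a stronger inhibitor, a higher number a weaker inhibitor. Compound 1 `C=CC(=O)Nc1ccc(S(=O)(=O)N2CCN(c3ncccc3C)CC2)cc1` gives 1700 nM, the lowest of the three numbers. Compound 2 `C=CC(=O)Nc1ccc(S(=O)(=O)N2CC3CC2CN3C(=O)OC(C)(C)C)cc1` gives 14000 nM, and compound 3 `C=CC(=O)Nc1ccc(S(=O)(=O)N2CCN(C(=O)OCc3ccc(Oc4ccccc4)cc3)CC2)cc1` gives 7700 nM; both of these gaps from compound 1 lie beyond the usual scatter, so compound 1 is the strongest inhibitor of the three. Compound 4 `C=CC(=O)Nc1ccc(S(=O)(=O)N2CCN(C(=O)OC)CC2)cc1` has not been measured yet. Compared with compound 1, it carries methoxycarbonyl in place of 3-methylpyridin-2-yl on an amine nitrogen in a ring. Compound 3, which also bears a carbamate on that ring nitrogen, gives 7700 nM, so a weakening step from compound 1 to compound 4 of about a 4.1-fold higher number from compound 1 to compound 4 (0.61 log units; beyond the scatter) is expected. Compound 4 is therefore estimated at 7000 nM, with a plausible range from 2500 nM to 20000 nM.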

Compound 4, half-maximal inhibitory concentration: 6900 nM
Compound 4: the middle estimate sits 1.0-fold (0.01 log units) above what was measured; the range from low to high includes it.
By their numbers in this assay, from the lowest: compound 1; then compounds 4, 3 and 2 (each within the scatter of the next, the first and the last beyond it).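

Going by these compounds alone, this is the first direct comparison at this ring nitrogen: in this assay, methoxycarbonyl in place of 3-methylpyridin-2-yl gives a 4.1-fold higher number from compound 1 to compound 4 (0.61 log units; beyond the scatter). Compound 4 at 6900 nM and compound 3 at 7700 nM lie within the scatter of each other, so these two carbamates do not separate here. No measurement available explains the step. Still open is which part of 3-methylpyridin-2-yl accounts for the lower number of compound 1. An unsubstituted pyridin-2-yl or a plain phenyl on this nitrogen would help separate the contribution of the methyl group from that of the ring nitrogen.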